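The source may hold more compounds than are shown below. What is called first, only, known or untested is meant among the compounds shown, and "the series" means these compounds.

Working notes on the series. Compound 1 `COc1ccc(F)cc1N1C(=O)CSC1c1cccc(C(=O)NCCCCc2ccccc2)c1` is the reference point: in a functional assay on 143B cells (Homo sapiens) for inhibition, read by CCK-8 assay, with a stated time of 72 h, tested at 1 uM (on this read-out higher numbers stand for more inhibition at the one concentration tested (going by the name of the read-out) and lower numbers for less inhibition), compound 1 gives 62%. Compound 2 `COc1cc(F)ccc1N1C(=O)CSC1c1cccc(C(=O)NCCCCc2ccccc2)c1` gives 63% in this assay, and compound 3 `CCOc1ccccc1N1C(=O)C(C)SC1c1cccc(C(=O)NCCCCc2ccccc2)c1` gives 53%. On these three numbers compound 1 sits with compound 2 on one side and compound 3 on the other, but its gap to either is within the usual scatter, so no order among the three can be read.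

Within the data shown here, the single measured step that touches the aryl group on the ring nitrogen is the change from compound 1 to compound 2 a number 1 percentage points higher from compound 1 to compound 2 (within the scatter), which moves the fluorine and leaves the number unchanged within the scatter.

Compound 4 `COc1ccc(N2C(=O)CSC2c2cccc(C(=O)NCCCCc3ccccc3)c2)c(OC)c1` differs from compound 1 as follows: 2,4-dimethoxyphenyl in place of 5-fluoro-2-methoxyphenyl on an amide-type nitrogen in a ring. Among the measured compounds shown here, this change removes the fluorine and brings in a second methoxy group; no measured step covers such a swap, and the one related step was flat. A step beyond the scatter is therefore not expected: the expected change is a number 2 percentage points lower from compound 1 to compound 4 (within the scatter). For compound 4 in this assay the estimate is 60%, expected to lie between 48% and 72%.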

Compound 4, a percentage reported as inhibition, at one concentration (the size of the read-out at that concentration, not a potency): 53%
The estimate for compound 4 lay 7 percentage points above the measured number, and the stated range covers the measured number.
By their numbers in this assay, from the lowest: compounds 3, 4, 1 and 2 (each within the scatter of the next).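

Among these compounds, at this position, on an amide-type nitrogen in a ring, the earlier compounds covered only a shift of the fluorine; a swap of the substituent pattern is now covered too. In this assay, the change to 2,4-dimethoxyphenyl reads as a number 9 percentage points lower from compound 1 to compound 4 (within the scatter), and methoxy in place of fluoro on an aromatic carbon reads as a number 10 percentage points lower from compound 2 to compound 4 (within the scatter), so a second methoxy group brings no readable loss against either fluorinated compound. No measured data bear on why the numbers fall as they do.

On these data alone, it remains open whether any substituent on this aryl ring moves the number beyond the scatter, for example a dimethylamino group or a carboxylic acid in the place of the fluorine. The compounds shown also leave open whether the aryl group can be replaced by a longer chain.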